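The compounds below may be only part of what the source reports. "The series", "measured", "known", "first", "only" and "open" are said of these compounds alone.

The series shares one core, shown by the structure of compound 1, `COC(=O)c1ccc(NCc2cncn2Cc2cccc(Br)c2)cc1-c1ccccc1`, and varies only the aryl group on a saturated chain carbon bound to an aromatic nitrogen. In a toxicity assay on NIH3T3 cells (Mus musculus) for cytotoxicity, read by resazurin assay (a higher number here means that more compound is needed for the effect, a lower number that less compound is needed), compound 1 gives > 10000 nM, which is a limit of the assay and not a number. Compound 2, `COC(=O)c1ccc(NCc2cncn2Cc2ccccc2C)cc1-c1ccccc1`, in this assay gives 10000 nM. The step of a number no higher from compound 1 to compound 2 (the limit leaves the size open) therefore has no readable size. Compound 3, `COC(=O)c1ccc(NCc2cncn2Cc2ccccc2-c2ccccc2)cc1-c1ccccc1`, has no number in this assay: its result is "not determined" (no result reported), so it stands nowhere on the scale, and the only other point of reference is the limit of > 10000 nM in this assay, at which 1 of the 3 values shown sits.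

Compound 4, `COC(=O)c1ccc(NCc2cncn2Cc2cccc(F)c2)cc1-c1ccccc1`, arises from compound 3 by the change (3-fluorophenyl in place of 2-phenylphenyl on a saturated chain carbon bound to an aromatic nitrogen). Among the measured compounds shown here, no measured step shares this change, and compound 3 itself offers no value to step from, so the expectation rests only on compounds 1 and 2, both sitting at the upper edge of what this assay reports. On that basis compound 4 is expected to behave much like them, with an estimated value in this assay of 10000 nM, within a range from 4000 nM to 30000 nM, and a real chance that only a limit is returned.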

Compound 4, half-maximal effective concentration: > 1000 nM
Compound 4 was reported as a limit (the forecaster's own chance of this, stated with the estimate: 60%); the middle value does not contradict the limit.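

In this assay compound 4 gives > 1000 nM, which is a limit of the assay and not a number. Among the compounds shown here, no step from compound 1 or compound 2 to compound 4 can be read. The compounds shown leave open whether swapping the aryl group on a saturated chain carbon bound to an aromatic nitrogen shifts the value in this assay at all.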